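Methylsulfanyl in place of chloro on the shared core

The source may report more compounds than this note shows. Statements on the series, on what has been measured and on what is new or still open speak of the compounds shown alone.

Of the compounds shown here, three sharing one core have been tested in a functional assay on the whole organism for inhibition, with Digitaria ciliaris as the target, with a stated time of 72 h, tested at 10 mg/L; on this read-out lower numbers stand for less inhibition of growth and higher numbers for more inhibition of growth at the one concentration tested. Compound 1 `COc1cc(C)nc2n/c(=N/C(=O)c3c(-c4ccc(Cl)cc4Cl)noc3C)sn12` gives 50.3%. Compound 2 `COc1cc(OC)n2s/c(=N\C(=O)c3c(-c4ccc(Cl)cc4Cl)noc3C)nc2n1` gives 53.8%, and the change of methoxy for methyl on an aromatic carbon shows a number 3.5 percentage points higher from compound 1 to compound 2 (within the scatter). Compound 3 `COc1cc(Cl)nc2n/c(=N/C(=O)c3c(-c4ccc(Cl)cc4Cl)noc3C)sn12` gives 16.5%, the lowest of the three numbers; the step of a number 33.8 percentage points lower from compound 1 to compound 3 (beyond the scatter) and the step of a number 37.3 percentage points lower from compound 2 to compound 3 (beyond the scatter) both show that putting chloro on this aromatic carbon, next to the ring nitrogen, reduced growth inhibition markedly.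

Compound 4 `COc1cc(SC)nc2n/c(=N/C(=O)c3c(-c4ccc(Cl)cc4Cl)noc3C)sn12` has not been measured. It differs from compound 3 by methylsulfanyl in place of chloro on an aromatic carbon. Within the data shown here, no measured pair exchanges chloro for methylsulfanyl, so the expectation rests on the pattern that chloro at this position gave the weakest inhibition, whereas methyl and methoxy there gave higher numbers. A methylsulfanyl group is expected to move the value back toward those of compounds 1 and 2, though not necessarily all the way, so the estimate for compound 4 is 42%, within 18% to 66%. This means an expected step of a number 25.5 percentage points higher from compound 3 to compound 4 (beyond the scatter), an increase in inhibition beyond the scatter, made with moderate confidence.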

Compound 4, percent growth inhibition at one concentration: 19.8%
The estimate for compound 4 lay 22.2 percentage points above the measured number, within the range that was stated.
By their numbers in this assay, from the lowest: compounds 3 and 4 (each within the scatter of the next); then compounds 1 and 2 (each within the scatter of the next).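

In this assay, the exchange of chloro for methylsulfanyl gives a number 3.3 percentage points higher from compound 3 to compound 4 (within the scatter), so on this aromatic carbon, next to the ring nitrogen, a low number is not confined to chloro. Methylsulfanyl also stands apart from the two groups that gave the higher numbers, with a number 34 percentage points lower from compound 2 to compound 4 (beyond the scatter) and a number 30.5 percentage points lower from compound 1 to compound 4 (beyond the scatter); the step from methoxy is notable, since the two groups differ by sulfur in place of oxygen. The four compounds thus fall into two sets, chloro with methylsulfanyl and methyl with methoxy, and none of the four goes against this split, though four groups on one core and at one concentration make a small basis for any wider rule.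

Going by these compounds, whether other groups on this carbon would join the higher or the lower set stays open, for example a dimethylamino group, a hydroxyl or a longer chain such as ethylsulfanyl. Nothing else given here bears on why these groups divide as they do.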